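This account rests on a few compounds, and the source may have more. Where it says the series, first, only, none or still open, it means among the compounds named here.

Compound 1 `O=C1c2ccccc2N(COCc2ccccc2)S(=O)(=O)N1COCc1ccccc1` gives in a functional assay on HEL cells (Homo sapiens) for inhibition (on this read-out higher numbers stand for lower toxicity in this test and lower numbers for higher toxicity in this test), a value of 130000 nM. Compound 2 `O=C1c2ccccc2N(Cc2ccccc2Cl)S(=O)(=O)N1COCc1ccccc1` gives in this assay only a limit, > 50000 nM.

Compound 2 thus stands at a limit and not at a number, so the step that the limit leaves unreadable from compound 1 to compound 2 cannot be sized, because the limit of > 50000 nM in this assay, at which 1 of the 2 values shown sits, hides where compound 2 actually lies. Compound 3 `O=C1c2ccccc2N(Cc2ccccc2)S(=O)(=O)N1COCc1ccccc1` differs from compound 2 in one place: hydrogen in place of chloro on an aromatic carbon. No measured step bears on this change; the only step shown, from compound 1 to compound 2, is itself unreadable, so no direction can be taken from it. With both measured compounds sitting at or beyond very high concentrations, compound 3 is expected to stay in the same region, and the step that the limit leaves unreadable from compound 2 to compound 3 is estimated to be none beyond the scatter. For compound 3 the estimate in this assay is 100000 nM, with a range from 40000 nM to 300000 nM, and a limit rather than a number is thought likely.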

Compound 3, half-maximal cytotoxic concentration: > 98000 nM
Compound 3: a limit, no number (the forecaster's own chance of this, stated with the estimate: 60%); the middle value lies beyond the limit too.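

In this assay compound 3 gives only a limit, > 98000 nM. Among these compounds, with compound 2 also at a limit, no step among compound 1, compound 2 and compound 3 can be read. On these data alone, whether hydrogen in place of chloro, or phenyl in place of benzyloxy, shifts the half-maximal cytotoxic concentration at all stays open.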